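Extending the Methoxy Group of Compound 2

The source may hold more compounds than are shown below. What is called first, only, known or untested is meant among the compounds shown, and "the series" means these compounds.

Among the compounds with values here, in a functional assay on LoVo cells (Homo sapiens) for inhibition, read by colorimetric assay and MTT assay, with a stated time of 72 h (on this read-out lower numbers stand for stronger inhibition and higher numbers for weaker inhibition), compound 1 `C=CCCCCCOc1ncc(-c2ccccc2OCCCCC=C)n1C` gives 32000 nM and compound 2 `C=CCCCCOc1ccccc1-c1cnc(OC)n1C` gives 47000 nM as the only other number, within the scatter of the first. Compound 3 `C=CCCCCOc1ccccc1-c1cnc(OCCOCC=C)n1C` turns the methoxy of compound 2 into 2-(allyloxy)ethoxy through the change (allyloxy)methyl in place of hydrogen on a saturated chain carbon bound to an oxygen on an aromatic ring and nothing else. Within the data shown here, the one measured step at this place is a 1.5-fold higher number from compound 1 to compound 2 (0.17 log units; within the scatter) and it stayed within the scatter even though hex-5-en-1-yl gave way to hydrogen. No shift beyond the scatter is therefore expected in this assay and the estimated step is a 1.2-fold lower number from compound 2 to compound 3 (0.09 log units; within the scatter) in size. Compound 3 is expected at 38000 nM with 17000 nM to 85000 nM as the estimated range.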

Compound 3, half-maximal inhibitory concentration: 26000 nM
Compound 3: middle estimate off by 1.5-fold (0.16 log units), on the high side; low and high end bracket the measured number.
By their numbers in this assay, from the lowest: compounds 3, 1 and 2 (each within the scatter of the next).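

In this assay the longer 2-(allyloxy)ethoxy in place of methoxy gives a 1.8-fold lower number from compound 2 to compound 3 (0.26 log units; within the scatter) and stays within the scatter, so this position takes the added chain without a clear shift. Allyloxy in place of pent-4-en-1-yl gives a 1.2-fold lower number from compound 1 to compound 3 (0.09 log units; within the scatter) and also stays within the scatter, so an oxygen and a carbon at that place in the chain cannot be told apart here. No measurement bearing on the reason is at hand. Still open, as far as these compounds go, is whether an amine or a carboxylic acid at the end of this chain would move the number beyond the scatter.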